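The compounds below may be only part of what the source reports. "The series", "measured", "known", "first", "only" and "open" are said of these compounds alone.

Compound 3 `Cn1c(-c2ccccc2C(F)(F)F)nnc1C12CCC(COc3ccc(S(C)(=O)=O)cc3)(CC1)CC2` stands, in an assay on CHO-K1 cells for inhibition of 11-beta-hydroxysteroid dehydrogenase type 2 (Mus musculus), read by scintillation proximity assay (a higher number here means a weaker inhibitor, a lower number a stronger inhibitor), at a limit rather than at a number: compound 3 gives > 4000 nM. Compound 1 `Cn1c(-c2ccccc2C(F)(F)F)nnc1C12CCC(CCS(=O)(=O)C(C)(C)C)(CC1)CC2` also gives only a limit there, > 4000 nM. Compound 2 `CC(C)S(=O)(=O)CCC12CCC(c3nnc(-c4ccccc4C(F)(F)F)n3C)(CC1)CC2` likewise gives a limit, > 4000 nM. All three values sit at the same limit, (the limit of > 4000 nM in this assay, at which 3 of the 3 values shown sit), so the steps among them cannot be read: a step that the two limits leave unreadable from compound 1 to compound 2, a step that the two limits leave unreadable from compound 1 to compound 3 and a step that the two limits leave unreadable from compound 2 to compound 3. Compound 4 `CCS(=O)(=O)CCCCC12CCC(c3nnc(-c4ccccc4C(F)(F)F)n3C)(CC1)CC2` differs from compound 3 in one place: 3-(ethylsulfonyl)propyl in place of 4-(methylsulfonyl)phenoxy on a saturated chain carbon bound to a saturated ring carbon. The change leads from the 4-(methylsulfonyl)phenoxy of compound 3 to a sulfonyl chain of the kind carried by compound 1 and compound 2, which both stand at the limit. Within the data shown here, no measured step has a readable size, so no direction beyond the scatter can be drawn from them; what they show is that all three compounds reached the limit of this assay. Compound 4 is therefore expected to sit at or near that limit, with an estimated step that the limit leaves unreadable from compound 3 to compound 4. The estimate for compound 4 in this assay is 8000 nM, with a range from 2000 nM to 40000 nM.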

Compound 4, half-maximal inhibitory concentration: > 4000 nM
Compound 4: a limit, no number (the forecaster's own chance of this, stated with the estimate: 85%); the middle value lies beyond the limit too.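

In this assay compound 4 gives > 4000 nM as a limit and not a number. The steps to it from compound 1, compound 2 and compound 3 therefore cannot be read: the limit of > 4000 nM in this assay, at which 4 of the 4 values shown sit. The compounds shown leave open whether any change among them alters the value in this assay at all, and how far beyond the limit each lies.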